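A few compounds are considered here, and "the series" means these few. Any claim that something is new, unique, unknown or untested is made for them only; others in the source may bear on it.

The series is built on one shared core carrying an isopropyl group and a meta-substituted anilino arm that bears a pyrimidine; the compounds differ in the group on the remaining position of the core and in the drawing of a stereocentre on the side chain. Compound 1 `CC(C)n1cnc2c(Nc3cccc(-c4cncnc4)c3)nc(Cl)nc21` carries a chlorine there, and in an assay on isolated protein (Asteroidea) for inhibition of G2/mitotic-specific cyclin-B (Asterina pectinifera), read by scintillation counting and 33P incorporation, with a stated time of 30 min (on this read-out lower numbers stand for stronger inhibition and higher numbers for weaker inhibition), compound 1 gives "not determined" (no result reported). Compound 2 `CCC[C@H](O)Nc1nc(Nc2cccc(-c3ncccn3)c2)c2ncn(C(C)C)c2n1` replaces the chlorine with a hydroxylated butyl chain attached through nitrogen, and in this assay compound 2 gives 730 nM. Compound 3 `CCC[C@@H](O)Nc1nc(Nc2cccc(-c3cncnc3)c2)c2ncn(C(C)C)c2n1` carries the same chain, drawn with the opposite configuration, and a differently connected pyrimidine; in this assay compound 3 gives 130 nM, the lowest of the two numbers reported, with compound 2 standing beyond the usual scatter above it.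

The step from compound 3 to compound 4 `CCC[C@H](O)Nc1nc(Nc2cccc(-c3cncnc3)c2)c2ncn(C(C)C)c2n1` is a pure change of configuration: the two compounds have the same atoms and bonds and differ only in configuration as drawn: 1 of 1 stereo elements differ; a stereocentre at a saturated chain carbon is drawn R in compound 3 and S in compound 4. Among the compounds with values here, no measured pair in this set differs in this way alone, so the size of the step is open. The author expects the drawn inversion to cost some potency, with the number rising moderately beyond the scatter, as in a 3.1-fold higher number from compound 3 to compound 4 (0.49 log units; beyond the scatter). Compound 4 is accordingly estimated at 400 nM in this assay, with a plausible range from 100 nM to 1500 nM.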

Compound 4, half-maximal inhibitory concentration: 300 nM
Compound 4: the middle estimate sits 1.3-fold (0.12 log units) above what was measured; measured number inside the range.
By their numbers in this assay, from the lowest: compound 3; then compound 4; then compound 2.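

In this assay, the drawn configuration of the hydroxylated butyl chain matters on its own, with the change from R to S giving a modest step (a 2.3-fold higher number from compound 3 to compound 4 (0.36 log units; beyond the scatter)). With compound 4 in the set, the attachment of the pyrimidine can also be read alone, with the chain drawn the same way in both compounds: pyrimidin-5-yl in place of pyrimidin-2-yl on an aromatic carbon gives a modest step as well (a 2.4-fold lower number from compound 2 to compound 4 (0.39 log units; beyond the scatter)). Compound 2 and compound 3 differ in both places, so their gap could not be divided, whereas each change now has its own step beyond the scatter, and the first can be assigned to the stereocentre alone because nothing else separates that pair: the fact that compounds 3 and 4 differ only in the configuration as drawn.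

The compounds shown leave open whether the configuration has the same effect on a compound carrying pyrimidin-2-yl as on one carrying pyrimidin-5-yl. They also leave open how the chain compares with the chlorine of compound 1, which has no reported result, and how a plain butylamine, a longer chain or a carboxylic acid would read at this position.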